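The source may hold more compounds than are shown below. What is called first, only, known or untested is meant among the compounds shown, and "the series" means these compounds.

Compound 1 `CCS(=O)(=O)Nc1cc(-c2ccc3ncnc(Nc4ccc(F)cc4F)c3c2)cnc1OC` belongs to a set of three measured compounds that share one core and differ only in the aryl group carried on the nitrogen on the aromatic ring. In a functional assay on A549 cells (Homo sapiens) for cytotoxicity, read by sulforhodamine B assay, with a stated time of 72 h (on this read-out higher numbers stand for weaker inhibition and lower numbers for stronger inhibition), compound 1 gives 4710 nM, the lowest of the three numbers. Compound 3 `CCS(=O)(=O)Nc1cc(-c2ccc3ncnc(Nc4ccc(OC)c(OC)c4)c3c2)cnc1OC` gives 5820 nM in this assay, and the step of a 1.2-fold higher number from compound 1 to compound 3 (0.09 log units; within the scatter) lies within the scatter. Compound 2 `CCS(=O)(=O)Nc1cc(-c2ccc3ncnc(Nc4ccc(OC(F)(F)F)cc4)c3c2)cnc1OC` gives 25400 nM, and the step of a 5.4-fold higher number from compound 1 to compound 2 (0.73 log units; beyond the scatter) lies beyond the scatter. Compound 4 `CCS(=O)(=O)Nc1cc(-c2ccc3ncnc(Nc4ccc(F)c(C(=O)OC)c4)c3c2)cnc1OC` has not yet been measured; it differs from compound 1 by 4-fluoro-3-(methoxycarbonyl)phenyl in place of 2,4-difluorophenyl on a nitrogen on an aromatic ring. The two measured steps that bear on this change exchange the same aryl group on the same nitrogen: a 1.2-fold higher number from compound 1 to compound 3 (0.09 log units; within the scatter) and a 5.4-fold higher number from compound 1 to compound 2 (0.73 log units; beyond the scatter). Neither brings the number below that of compound 1, and one raises it modestly. On that basis the step expected for compound 4 is a 1.7-fold higher number from compound 1 to compound 4 (0.23 log units; within the scatter), a small rise or none beyond the scatter. The estimate for compound 4 in this assay is 8000 nM, with a range from 2500 nM to 25000 nM.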

Compound 4, half-maximal inhibitory concentration: 3420 nM
Estimate against measurement, compound 4: 2.3-fold (0.37 log units) above; the range from low to high includes it.
By their numbers in this assay, from the lowest: compounds 4, 1 and 3 (each within the scatter of the next); then compound 2.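

In this assay, the 4-fluoro-3-(methoxycarbonyl)phenyl group joins the group of compounds with the lower numbers: a 1.4-fold lower number from compound 1 to compound 4 (0.14 log units; within the scatter) and a 1.7-fold lower number from compound 3 to compound 4 (0.23 log units; within the scatter) both stay within the scatter, whereas a 7.4-fold lower number from compound 2 to compound 4 (0.87 log units; beyond the scatter) lies beyond it. For the compounds shown here, this nitrogen on an aromatic ring therefore tolerates an aryl group with more heavy atoms, a double bond outside the ring and hydrogen-bond acceptors, with no step from compound 1 beyond the scatter. Among the four compounds, only compound 2 now stands apart from the rest, and no aryl group shown gives a number clearly lower than that of compound 1.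

Going by these compounds, what a carboxylic acid or a primary amide in place of the methyl ester would give remains open, as does what the ring fluorine contributes. No measurement shown accounts for any of these steps.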